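Azido to ethyl on a fluorinated nucleoside

The compounds below may be only part of what the source reports. "The series", "measured", "known", "first", "only" and "open" are said of these compounds alone.

Measured in a functional assay on MCF7 cells (Homo sapiens) for antiproliferative activity, read by WST assay, with a stated time of 3 days; on this read-out higher numbers stand for weaker inhibition and lower numbers for stronger inhibition:
- Compound 1 `O=c1cc(I)n([C@@H]2O[C@H](CO)[C@@H](O)[C@H]2O)c(=O)[nH]1`: > 50000 nM (a limit)
- Compound 2 `[N-]=[N+]=Nc1cc(=O)[nH]c(=O)n1[C@@H]1O[C@H](CO)[C@@H](O)[C@H]1O`: > 50000 nM (a limit)
- Compound 3 `[N-]=[N+]=Nc1c(F)c(=O)[nH]c(=O)n1[C@@H]1O[C@H](CO)[C@@H](O)[C@H]1O`: 1000 nM

For the measured compounds named here, compound 3 is the only compound here with a true number in this assay, at 1000 nM. The other two readings are limits, and the scale ends close by: the limit of > 50000 nM in this assay, at which 2 of the 3 values shown sit.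

Compound 4 `CCc1c(F)c(=O)[nH]c(=O)n1[C@@H]1O[C@H](CO)[C@@H](O)[C@H]1O` has not yet been measured. It carries ethyl in place of azido on an aromatic carbon, next to the ring nitrogen and ortho to a fluoro group: ethyl in place of azido on an aromatic carbon.

Going by the values given here, no measured step makes this exchange. The nearest step that also changes the azido group is a step that the two limits leave unreadable from compound 1 to compound 2, which gives no size. Fluoro in place of hydrogen gave an at least 50-fold lower number from compound 2 to compound 3 (1.69 log units; beyond the scatter), a large change beyond the scatter. Among the compounds with values here, compound 4 keeps that fluoro group, but compound 3 is the only measured compound that has both azido and fluoro, and it alone reads 1000 nM. Losing the azido group is therefore expected to give a clearly weaker result, not one within the scatter. The expected change is a 15-fold higher number from compound 3 to compound 4 (1.18 log units; beyond the scatter). A reading at the limit would fit this expectation too.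

Compound 4 is estimated at 15000 nM, with an expected range of 3000 nM to 50000 nM.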

Compound 4, half-maximal inhibitory concentration: 31400 nM
Estimate against measurement, compound 4: 2.1-fold (0.32 log units) below; the measured number falls inside the stated range.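

In this assay, ethyl in place of azido gives a 31-fold higher number from compound 3 to compound 4 (1.50 log units; beyond the scatter), so this aromatic carbon, ortho to a fluoro group, is sensitive to what it carries. For the compounds shown here, the earlier compounds could not show this: the only other step that changed the azido group ran between two limits and gave no size, and the fluoro step showed the effect of adding fluoro only with azido kept in place. Compound 4 keeps the fluoro group and loses most of the activity seen for compound 3 at 1000 nM, so among the compounds shown, fluoro without azido is not enough for that reading, although compound 4 still gives a true number and not a limit.

The compounds shown leave open whether azido itself is required or whether another group on this carbon, such as an amine, a nitrile or a methoxy group, would keep the reading of compound 3. They also leave open what ethyl does without the fluoro group, and whether a longer chain here would read differently from ethyl.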